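A few compounds are considered here, and "the series" means these few. Any claim that something is new, unique, unknown or untested is made for them only; others in the source may bear on it.

Three compounds share one core and differ only in the aryl group carried on the piperazine nitrogen. Compound 1 `Nc1scc(CN2CCN(c3ccc(OC(F)(F)F)cc3)CC2)c1C(=O)c1ccc(Cl)cc1` gives 1% in an assay on CHO cells for displacement of a labelled ligand from adenosine receptor A3 (Homo sapiens), read by scintillation counting, with a stated time of 120 min, tested at 10 uM; on this read-out lower numbers stand for less inhibition and higher numbers for more inhibition at the one concentration tested (going by the name of the read-out). Compound 2 `Nc1scc(CN2CCN(c3ccccc3F)CC2)c1C(=O)c1ccc(Cl)cc1` gives 0%, and compound 3 `Nc1scc(CN2CCN(c3ccc(F)c(F)c3)CC2)c1C(=O)c1ccc(Cl)cc1` gives 1%. All three numbers lie close to zero: the step of a number 1 percentage points lower from compound 1 to compound 2 (within the scatter), the step of no change at the digits printed from compound 1 to compound 3 (within the scatter) and the step of a number 1 percentage points higher from compound 2 to compound 3 (within the scatter) are each within the usual scatter, so compound 3 stands level with compound 1 and is not separated from compound 2 either.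

Compound 4 `Nc1scc(CN2CCN(CCCc3ccc(Cl)cc3)CC2)c1C(=O)c1ccc(Cl)cc1` changes the same position: 3-(4-chlorophenyl)propyl in place of 3,4-difluorophenyl on an amine nitrogen in a ring. Among the measured compounds shown here, none of the measured steps covers this kind of change, since all of them swap one aryl group for another, and each of those swaps left the reading unchanged within scatter. The data give no reason to expect a step beyond the scatter here. Compound 4 is expected to give an estimated 2% in this assay, between -8% and 14%. This corresponds to an expected step of a number 1 percentage points higher from compound 3 to compound 4 (within the scatter).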

Compound 4, a percentage reported as inhibition, at one concentration (the size of the read-out at that concentration, not a potency): 0%
Beside the measured number, compound 4's estimate is 2 percentage points above it; low and high end bracket the measured number.
By their numbers in this assay, from the lowest: compounds 2, 4, 1 and 3 (each within the scatter of the next).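

In this assay, the steps of a number 1 percentage points lower from compound 3 to compound 4 (within the scatter) and no change at the digits printed from compound 2 to compound 4 (within the scatter) and a number 1 percentage points lower from compound 1 to compound 4 (within the scatter) show that 3-(4-chlorophenyl)propyl, with 10 heavy atoms, reads the same within scatter as each of the smaller aryl groups it replaces. The earlier steps shown here only swapped one aryl group for another, so the flat result now also covers a group that holds its aromatic ring on a propyl chain. Nothing shown here explains why the readings stay close to zero.

Every group so far on this amine nitrogen carries a six-membered aromatic ring of carbon only, so a pyridine ring, a chain ending in a carboxylic acid or a chain ending in an amine could still behave differently. Changes to the shared core away from this position also remain open.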